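This account rests on a few compounds, and the source may have more. Where it says the series, first, only, none or still open, it means among the compounds named here.

Working notes on the shared core, variation at the saturated chain carbon bound to an amine nitrogen in a ring.

Compound 3 `CCOC(=O)c1cnc(N2CCN(Cc3ccccc3F)CC2)nc1Oc1c(C)cc(-c2ccc(C#N)cc2)cc1C` carries a 2-fluorophenyl at that position. In an ADME assay on MT4 cells (Homo sapiens) for cytotoxicity, read by MTT assay, with a stated time of 4 days (on this read-out higher numbers stand for lower toxicity in this test and lower numbers for higher toxicity in this test), compound 3 gives only a limit, > 125000 nM. Compound 1 `CCOC(=O)c1cnc(N2CCN(Cc3cccc(C#N)c3)CC2)nc1Oc1c(C)cc(-c2ccc(C#N)cc2)cc1C`, with a 3-cyanophenyl there, likewise gives a limit in this assay, > 125000 nM. Compound 2 `CCOC(=O)c1cnc(N2CCN(Cc3ccc(C(F)(F)F)cc3)CC2)nc1Oc1c(C)cc(-c2ccc(C#N)cc2)cc1C`, with a 4-(trifluoromethyl)phenyl, again gives a limit in this assay, > 125000 nM. Of compound 3 it can therefore be said only that it sits at the limit, together with the other two values shown, because of the limit of > 125000 nM in this assay, at which 3 of the 3 values shown sit.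

The measured steps between these three are all unreadable: a step that the two limits leave unreadable from compound 1 to compound 2, a step that the two limits leave unreadable from compound 1 to compound 3 and a step that the two limits leave unreadable from compound 2 to compound 3, each bounded on both sides by the limit, so their size is not known.

Compound 4 `CCOC(=O)c1cnc(N2CCN(Cc3cccc(Br)c3)CC2)nc1Oc1c(C)cc(-c2ccc(C#N)cc2)cc1C` differs from compound 3 by 3-bromophenyl in place of 2-fluorophenyl on a saturated chain carbon bound to an amine nitrogen in a ring. For the measured compounds named here, all three steps that bear on this position end at the limit, so no direction and no size can be read for this assay; nothing among the measured compounds points to a step beyond the scatter. The expected step that the limit leaves unreadable from compound 3 to compound 4 is accordingly small. Compound 4 is expected to sit at 150000 nM, within 60000 nM to 400000 nM, most likely reported again as a limit.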

Compound 4, half-maximal cytotoxic concentration: > 125000 nM
Compound 4: a limit, no number; the forecaster's own chance of this, stated with the estimate: 80%; the middle value is on the limit's open side.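

In this assay compound 4 gives > 125000 nM as a limit and not a number. No new step can be read between compound 4 and compound 1, compound 2 or compound 3, since all four sit at the same limit: the limit of > 125000 nM in this assay, at which 4 of the 4 values shown sit. The compounds shown leave open whether the group at this position alters the read-out at all.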